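This account rests on a few compounds, and the source may have more. Where it says the series, first, only, none or still open, it means among the compounds named here.

Of the compounds shown here, two carry numbers so far. In an assay on COS-7 cells for inhibition of patatin-like phospholipase domain-containing protein 2 (Mus musculus) (on this read-out lower numbers stand for stronger inhibition and higher numbers for weaker inhibition), compound 1 `CCOC(=O)c1cccc(-c2ccc3c(ccn3C)c2)c1` gives 75000 nM. In this assay compound 2 `CCOc1ccc(-c2cccc(S(=O)(=O)NC)c2)cc1` gives 200000 nM, which is the higher of the two numbers, and its gap to compound 1 lies beyond the scatter, so compound 2 is the weaker inhibitor of this pair. Compound 3 `CCOc1ccc(-c2cccc([N+](=O)[O-])c2)cc1` has not been measured yet. It shares the core of compound 2 and differs from it in one place: nitro in place of methylsulfamoyl on an aromatic carbon. Going by the values given here, no measured pair shows what this exchange does, so the two numbers give nothing to lean on beyond the fact that compound 2 already stands at a high value. With no guide of that kind, the step of no change at the digits printed from compound 2 to compound 3 (within the scatter) is expected to stay within the scatter, in neither direction in particular. Compound 3 is thus expected to give about 200000 nM in this assay, with a range from 60000 nM to 600000 nM, and a fair chance that only a limit and no number is reported.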

Compound 3, half-maximal inhibitory concentration: > 200000 nM
Compound 3: a limit, no number; the forecaster's own chance of this, stated with the estimate: 40%; the middle value lies on the limit itself.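

Going by these compounds alone, the exchange of methylsulfamoyl for nitro on this aromatic carbon gives a number no lower from compound 2 to compound 3 (the limit leaves the size open), and this is the first direct view of a change at this place. In this assay compound 3 gives > 200000 nM, which is a limit of the assay and not a number: the limit of > 200000 nM in this assay, at which 1 of the 3 values shown sits. Nitro has fewer heavy atoms than methylsulfamoyl and no hydrogen-bond donor, yet the exchange brings no lower number, so neither of these two differences comes with stronger inhibition in this one pair, and how large the step is cannot be read.

From the compounds shown here alone, what stays open is how far compound 3 really lies from compound 2, and whether any group on this aromatic carbon can bring the number down at all. A carboxylic acid or an amine in the same place would be a different kind of group from the two seen here, and the compounds shown say nothing about how either would behave.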